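One Methoxy Fewer on Compound 1

The compounds below may be only part of what the source reports. "The series", "measured", "known", "first", "only" and "open" are said of these compounds alone.

Measured compounds:
compound 1 `COc1cc(C2=NOC(c3c[nH]c4ccccc34)C2)cc(OC)c1OC` — 4510 nM
compound 2 `Cc1[nH]c2ccccc2c1C1CC(c2ccncc2)=NO1` — 17300 nM
compound 3 `Clc1ccc(Cn2cc(C3CC(c4ccncc4)=NO3)c3ccccc32)cc1` — 9600 nM

In a functional assay on CWR22R cells (Homo sapiens) for inhibition, read by MTT assay, with a stated time of 48 h (on this read-out lower numbers stand for stronger inhibition and higher numbers for weaker inhibition), compound 1 gives the lowest number of the three; compound 3 stands nearest and compound 2 furthest, both differences lying beyond the scatter. Compound 4 `COc1ccc(C2=NOC(c3c[nH]c4ccccc34)C2)cc1OC` differs from compound 1 by hydrogen in place of methoxy on an aromatic carbon. Going by the values given here, no measured pair shows this change, so the size of the step is open. A modest move toward weaker inhibition is expected, of about the size of the gaps seen among the measured compounds, though a step within the scatter cannot be excluded. Compound 4 is therefore expected to give about 9000 nM, in the range 3000 nM to 30000 nM in this assay. The expected step is a 2.0-fold higher number from compound 1 to compound 4 (0.30 log units; within the scatter).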

Compound 4, half-maximal inhibitory concentration: 16700 nM
Beside the measured number, compound 4's estimate is 1.9-fold (0.27 log units) below it; the measured number falls inside the stated range.
By their numbers in this assay, from the lowest: compound 1; then compounds 3, 4 and 2 (each within the scatter of the next).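

In this assay, hydrogen in place of methoxy on the aromatic carbon ortho to a methoxy group and meta to a large group gives a 3.7-fold higher number from compound 1 to compound 4 (0.57 log units; beyond the scatter). This is the first single-place comparison among these compounds, and it shows that, at this position, the number depends on the methoxy group. Nothing available explains the step. From the compounds shown here alone, whether an ethoxy group, a fluorine atom or an amine at this position would give a number closer to that of compound 1 remains open. So does whether this change would give a step of similar size on another compound.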